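Side-chain notes: from compound 3 to compound 4

A few compounds are considered here, and "the series" means these few. Any claim that something is new, unique, unknown or untested is made for them only; others in the source may bear on it.

Compound 1 `COC(=O)C1=C(CN2CCNCC2)NC(c2nccs2)=NC1(C)c1ccc(F)cc1` gives 250 ug/mL
Compound 2 `COC(=O)C1=C(CN2CCOCC2=O)NC(c2nccs2)=NC1(C)c1ccc(F)cc1` gives 440 ug/mL
Compound 3 `COC(=O)C1=C(CN2CCNC(=O)C2)NC(c2nccs2)=NC1(C)c1ccc(F)cc1` gives 34 ug/mL

In a physicochemical assay for solubility, read by HPLC, in phosphate buffer, at pH 6.5 (a higher number here means a more soluble compound, a lower number a less soluble compound), compound 3 stands lowest of the three, at 34 ug/mL. Compound 4 `COC(=O)C1=C(CN2CCC(O)C2)NC(c2nccs2)=NC1(C)c1ccc(F)cc1` differs from it as follows: 3-hydroxypyrrolidin-1-yl in place of 3-oxopiperazin-1-yl on a saturated chain carbon bound to a double-bonded ring carbon. Two measured steps also leave or enter at this place with 3-oxopiperazin-1-yl: a 7.4-fold lower number from compound 1 to compound 3 (0.87 log units; beyond the scatter) (modest) and a 13-fold lower number from compound 2 to compound 3 (1.11 log units; beyond the scatter) (large). The remaining step, a 1.8-fold higher number from compound 1 to compound 2 (0.25 log units; within the scatter), stays within the scatter. Among the measured compounds shown here, no measured compound carries 3-hydroxypyrrolidin-1-yl, so these steps are only an indirect guide. In this assay a modest rise beyond the scatter is expected, closer to the first step than the second. The estimated step is a 5.0-fold higher number from compound 3 to compound 4 (0.70 log units; beyond the scatter). For compound 4 the expected value is 170 ug/mL, within an estimated range of 60 ug/mL to 500 ug/mL.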

Compound 4, solubility: 503 ug/mL
The estimate for compound 4 lay 3.0-fold (0.47 log units) below the measured number, outside the stated range (above it).
By their numbers in this assay, from the lowest: compound 3; then compounds 1, 2 and 4 (each within the scatter of the next).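

The 3-hydroxypyrrolidin-1-yl and 3-oxopiperazin-1-yl groups have the same hydrogen-bond donor and acceptor counts and no net charge, yet in this assay the change gives a 15-fold higher number from compound 3 to compound 4 (1.17 log units; beyond the scatter) at this place, on a saturated chain carbon bound to a double-bonded ring carbon. Compound 3 now stands alone among the four, since the change to 3-hydroxypyrrolidin-1-yl gives a 1.1-fold higher number from compound 2 to compound 4 (0.06 log units; within the scatter) and a 2.0-fold higher number from compound 1 to compound 4 (0.30 log units; within the scatter), both within the scatter. No measurement on hand bears on the low number of compound 3.

From the compounds shown here alone, whether that low number is peculiar to 3-oxopiperazin-1-yl remains open, as does how an open-chain amine or a carboxylic acid would read at this place in this assay for comparison.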